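Amide variation on the chain bound to the ring nitrogen

The source may report more compounds than this note shows. Statements on the series, on what has been measured and on what is new or still open speak of the compounds shown alone.

Measured so far:
compound 1 `CCCCCCCCN(C)C(=O)Cn1cc(Cc2cnc(=O)n(C)c2)c(=O)nc1SCc1ccc(F)cc1`, 55%
compound 2 `CCCCCCCCN(C)C(=O)Cn1cc(Cc2cnc(=O)n(CC(=O)O)c2)c(=O)nc1SCc1ccc(F)cc1`, 56%
compound 3 `CCCCCCCCN(C)C(=O)Cn1cc(Cc2cnc(=O)n(CC(=O)NCCO)c2)c(=O)nc1SCc1ccc(F)cc1`, 68%

In a functional assay on a cell-free system (plasma) for inhibition of platelet-activating factor acetylhydrolase (Homo sapiens), tested at 100 nM (on this read-out lower numbers stand for less inhibition and higher numbers for more inhibition at the one concentration tested (going by the name of the read-out)), compound 3 stands highest of the three numbers; its nearest neighbour is compound 2, and compound 1 lies furthest away, both gaps beyond the scatter. The two steps into compound 3 were a number 13 percentage points higher from compound 1 to compound 3 (beyond the scatter) and a number 12 percentage points higher from compound 2 to compound 3 (beyond the scatter), while a number 1 percentage points higher from compound 1 to compound 2 (within the scatter) left the read-out where it was.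

Compound 4 `CCCCCCCCN(C)C(=O)Cn1cc(Cc2cnc(=O)n(CC(=O)N3CCN(C)CC3)c2)c(=O)nc1SCc1ccc(F)cc1` carries the next change at the same carbonyl carbon: 4-methylpiperazin-1-yl in place of (2-hydroxyethyl)amino on a carbonyl carbon. Going by the values given here, no measured pair covers this kind of swap. Among the compounds with values here, the only step that touches the carbonyl carbon, the one from compound 2 to compound 3, was modest, and the whole spread of the series so far is narrow. The change to compound 4 keeps an acceptor-bearing amide at that position while the two donors of the (2-hydroxyethyl)amino group are gone, so nothing measured argues for a step beyond the scatter in either direction, and a number somewhat below compound 3 is expected.

For compound 4 the estimate in this assay is 62% with a range of 47% to 76%, which means an expected step of a number 6 percentage points lower from compound 3 to compound 4 (within the scatter).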

Compound 4, a percentage reported as inhibition, at one concentration (the size of the read-out at that concentration, not a potency): 68%
Beside the measured number, compound 4's estimate is 6 percentage points below it; the range from low to high includes it.
By their numbers in this assay, from the lowest: compounds 1 and 2 (each within the scatter of the next); then compounds 3 and 4 (each within the scatter of the next).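

In this assay, 4-methylpiperazin-1-yl in place of (2-hydroxyethyl)amino on the carbonyl carbon gives no change at the digits printed from compound 3 to compound 4 (within the scatter), so this position accepts a six-membered non-aromatic ring and the loss of the hydrogen-bond donors of (2-hydroxyethyl)amino without a shift in the read-out. A second, quite different amide now also stands clear of the acid, with a number 12 percentage points higher from compound 2 to compound 4 (beyond the scatter), and of the methyl compound, with a number 13 percentage points higher from compound 1 to compound 4 (beyond the scatter), so the modest gain first seen with compound 3 is not tied to the (2-hydroxyethyl)amino group alone. No measurement at hand bears on why these two amides read alike.

Still open, as far as these compounds go, is whether the far nitrogen of 4-methylpiperazin-1-yl plays any part, which morpholin-4-yl on the same carbonyl carbon would test, and whether any ring is needed at all, which dimethylamino there would test. The read-out is also a single-concentration figure and not a potency, so any difference in potency between compound 3 and compound 4 remains undetermined.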